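Phenylsulfanyl in Place of Chloro: An Expected Shift

The source may hold more compounds than are shown below. What is called first, only, known or untested is meant among the compounds shown, and "the series" means these compounds.

Of the compounds shown here, three have been measured in a functional assay on cells (Neutrophil, Homo sapiens) for inhibition, read by WST assay, with a stated time of 20 min; on this read-out higher numbers stand for weaker inhibition and lower numbers for stronger inhibition. Compound 1 `CNC1=C(Cl)C(=O)c2ncccc2C1=O` gives 78900 nM, the highest of the three numbers. Compound 3 `CNC1=C(Cl)C(=O)c2cccnc2C1=O` gives 41100 nM, which lies within the usual scatter of the value of compound 1. Compound 2 `O=C1C(NC(c2ccccc2)c2ccccc2)=C(Cl)C(=O)c2ncccc21` gives 33900 nM, a lower number than that of compound 1 and beyond the scatter. Compound 4 `CNC1=C(Sc2ccccc2)C(=O)c2ncccc2C1=O` has not been measured; it differs from compound 1 by phenylsulfanyl in place of chloro on a double-bonded ring carbon. Among the compounds with values here, no measured pair shows this change, so the size of the step is uncertain. Compound 4 is expected to give 40000 nM, between 10000 nM and 150000 nM, in this assay, which would mean an expected step of a 2.0-fold lower number from compound 1 to compound 4 (0.30 log units; within the scatter), a modest move toward stronger inhibition that may not exceed the scatter.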

Compound 4, half-maximal inhibitory concentration: > 150000 nM
Compound 4: a limit, no number (the forecaster's own chance of this, stated with the estimate: 10%); at least 3.7-fold (0.57 log units) between middle value and limit.
By their numbers in this assay, from the lowest: compounds 2, 3 and 1 (each within the scatter of the next, the first and the last beyond it). At a limit, above all of these: compound 4.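

Compound 4 gives a limit of the assay, not a number: the limit of > 150000 nM in this assay, at which 1 of the 4 values shown sits. Within the data shown here, all the earlier compounds carry chloro at this carbon, so this is the first view of a change there: in this assay, phenylsulfanyl brings an at least 1.9-fold higher number from compound 1 to compound 4 (0.27 log units; that floor lies within the scatter). Its true size cannot be read, but the larger group gives no lower number here.

On these data alone, whether an amine, methoxy or a methyl group on this carbon would give a lower number stays open. So does how phenylsulfanyl behaves on the core of compound 3.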